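Acetyl in place of phenyl on compound 1

The source may report more compounds than this note shows. Statements on the series, on what has been measured and on what is new or still open speak of the compounds shown alone.

Compound 1 (`O=C(C1CCN(c2ccccc2)CC1)N1N=CC[C@H]1c1ccccc1`) gives 6.3
Compound 2 (`CC(C)(C)C(=O)n1nccc1-c1ccccc1`) gives 8.3

Both numbers come from a physicochemical assay for lipophilicity, read by HPLC, measured as chromatographic lipophilicity, at pH 7.4 (on this read-out higher numbers stand for higher lipophilicity and lower numbers for lower lipophilicity), and only these two compounds have been measured so far. Compound 1, at 6.3 and so the lower of the two, sits under compound 2 (8.3) by a gap beyond the usual scatter.

Compound 3 (`CC(=O)N1CCC(C(=O)N2N=CC[C@H]2c2ccccc2)CC1`) keeps the core of compound 1 but carries acetyl in place of phenyl on an amine nitrogen in a ring. For the measured compounds named here, no measured pair shows this swap, so the expectation rests on the structural change alone. A large step downward in this assay is expected, well beyond the scatter. The estimated size of the move is a number 2.30 log units lower from compound 1 to compound 3 (beyond the scatter) on this scale. Compound 3 is expected to read 4 with an estimated range from 3.2 to 4.8 once it is measured.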

Compound 3, distribution coefficient: 2.5
The estimate for compound 3 lay 1.50 log units above the measured number, and the stated range ends above it.
By their numbers in this assay, from the lowest: compound 3; then compound 1; then compound 2.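

In this assay, the amine nitrogen in a ring proves to be a place where the choice of group has a very large effect on the reading: replacing phenyl with acetyl gives a number 3.80 log units lower from compound 1 to compound 3 (beyond the scatter). This single swap changes several things at once, as a six-membered aromatic ring of carbon only leaves and a smaller group with a hydrogen-bond acceptor enters. No measurement available here shows which of these differences accounts for the size of the step.

The compounds shown leave open how the reading responds to other groups on this nitrogen, such as benzoyl, which pairs an aromatic ring with a carbonyl, or a simple methyl. For the compounds shown here, with only one pair showing this swap, it also remains open whether a similar step would appear on a different core.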